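Dropping the (2-Phenylethenyl)carbonyl Group: An Untested Step

The source may hold more compounds than are shown below. What is called first, only, known or untested is meant among the compounds shown, and "the series" means these compounds.

Compound 1 `Cc1cc(Nc2ccc(C(=O)/C=C/c3cccc(Br)n3)cc2)n2nc(SCc3nc4ccccc4[nH]3)nc2n1`: 94.4%
Compound 2 `Cc1cc(Nc2ccc(C(=O)/C=C/c3ccccc3)cc2)n2nc(SCc3nc4ccccc4[nH]3)nc2n1`: 94.5%

Both compounds were tested in a functional assay on MGC-803 cells (Homo sapiens) for inhibition, read by sulforhodamine B assay, with a stated time of 72 h, tested at 10 uM; on this read-out higher numbers stand for more inhibition at the one concentration tested (going by the name of the read-out) and lower numbers for less inhibition. Compound 2 gives 94.5%, and compound 1 gives 94.4%; the step of a number 0.1 percentage points higher from compound 1 to compound 2 (within the scatter) lies within the scatter, so the two cannot be told apart on these numbers. That single measured step swaps one ring at the far end of the chain, and the read-out did not move.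

Compound 3 `Cc1cc(Nc2ccccc2)n2nc(SCc3nc4ccccc4[nH]3)nc2n1` has not been measured. It differs from compound 2 by hydrogen in place of (2-phenylethenyl)carbonyl on an aromatic carbon. Among the compounds with values here, no measured step removes this group; the one step available touches only its outer ring and therefore gives no guide to taking the whole group away. The expectation is a weaker read-out, with wide uncertainty: a step of a number 44.5 percentage points lower from compound 2 to compound 3 (beyond the scatter) is expected, giving for compound 3 an estimated 50%, within the range 10% to 92%.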

Compound 3, a percentage reported as inhibition, at one concentration (the size of the read-out at that concentration, not a potency): 22.4%
Beside the measured number, compound 3's estimate is 27.6 percentage points above it, within the range that was stated.
By their numbers in this assay, from the lowest: compound 3; then compounds 1 and 2 (each within the scatter of the next).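

Within the data shown here, the one step measured earlier changed only the outer ring of the chain, so it said nothing about the group as a whole. Taking away the entire (2-phenylethenyl)carbonyl group in this assay gives a number 72.1 percentage points lower from compound 2 to compound 3 (beyond the scatter) and is no small change. Taking away the (2-(6-bromopyridin-2-yl)ethenyl)carbonyl group gives the same picture, with a number 72 percentage points lower from compound 1 to compound 3 (beyond the scatter) as the step, so at this aromatic carbon the read-out at the one concentration tested depends on having such a group there, whichever of these two outer rings it carries.

Still open, as far as these compounds go, is whether the whole group is needed or only part of it, which a lone acetyl group or an amine on the same aromatic carbon could help to settle. Nothing shown here gives a reason for the drop.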